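Working notes: from compound 2 to compound 3

A few compounds are considered here, and "the series" means these few. Any claim that something is new, unique, unknown or untested is made for them only; others in the source may bear on it.

Measured so far:
- compound 1, `C=C(Br)C(=O)Nc1cccc(-c2cn3nc(Cc4ccc(Cl)cc4)sc3n2)c1`, gives 2300 nM in a functional assay on L1210 cells (Mus musculus) for inhibition, read by cell counting, with a stated time of 2 days; a higher number here means a weaker inhibitor, a lower number a stronger inhibitor
- compound 2, `C=C(Br)C(=O)Nc1cccc(-c2cn3nc(CCc4ccccc4)sc3n2)c1`, gives 2200 nM in this assay

Compound 2 holds the lowest of the two numbers, but its nearest neighbour is compound 1, and the step of a 1.0-fold lower number from compound 1 to compound 2 (0.02 log units; within the scatter) is within the scatter, so the two are not distinguished.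

Compound 3, `C=C(Br)C(=O)Nc1cccc(-c2cn3nc(-c4ccc(OC)cc4)sc3n2)c1`, is the next candidate. The change from compound 2 is 4-methoxyphenyl in place of phenethyl on an aromatic carbon. Of the measured steps, only a 1.0-fold lower number from compound 1 to compound 2 (0.02 log units; within the scatter) is on hand, and it concerns a change on a saturated chain carbon, not a group placed directly on the aromatic carbon of the five-membered ring; it is within the scatter and gives no direction. Among the measured compounds shown here, no measured step bears directly on an aryl group placed on that ring carbon, so the expectation rests on compound 2 alone.

For compound 3 a value near that of compound 2 is expected, a step of a 1.1-fold lower number from compound 2 to compound 3 (0.04 log units; within the scatter) in this assay, with wide uncertainty in either direction: estimated 2000 nM, range 600 nM to 7000 nM.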

Compound 3, half-maximal inhibitory concentration: 940 nM
Compound 3: middle estimate off by 2.1-fold (0.33 log units), on the high side, within the range that was stated.
By their numbers in this assay, from the lowest: compound 3; then compounds 2 and 1 (each within the scatter of the next).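

At this aromatic carbon of the five-membered ring, the number in this assay does respond to the group placed there, with a 2.3-fold lower number from compound 2 to compound 3 (0.37 log units; beyond the scatter) on replacing phenethyl and a 2.4-fold lower number from compound 1 to compound 3 (0.39 log units; beyond the scatter) on replacing 4-chlorobenzyl, both modest but beyond the scatter. Among the compounds shown here, the earlier pair showed no such response, since a 1.0-fold lower number from compound 1 to compound 2 (0.02 log units; within the scatter) left the two chain-linked groups undistinguished, so compound 3, with its ring bound directly to this carbon, is the first to stand apart from them. Both new steps remove the saturated chain and add the methoxy group in a single change, so the two cannot be separated, and no supporting measurement accounts for the lower number.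

Still open, going by these compounds, is whether a plain phenyl or a 4-chlorophenyl bound directly at this carbon would match compound 3, which would show whether the direct attachment or the methoxy group goes with the lower number. Also open, on these data alone, is how this carbon would tolerate a different kind of group, such as an amine, a carboxylic acid or a longer chain ending in a phenyl ring.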